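Methoxy to hydroxy on the acetamido compound

This account rests on a few compounds, and the source may have more. Where it says the series, first, only, none or still open, it means among the compounds named here.

In a functional assay on HepG2 cells (Homo sapiens) for antiproliferative activity, read by MTT assay, with a stated time of 48 h (a lower number here means a stronger inhibitor, a higher number a weaker inhibitor), compound 1 `CCOc1ccc(Nc2c(-c3ccc(OC)cc3)c(=O)oc3cc(OC)ccc23)cc1` gives 31200 nM as a measured number. Compound 2 `COc1ccc(-c2c(Nc3ccc(C)cc3)c3ccc(OC)cc3oc2=O)cc1` gives 74400 nM in the same read-out. Compound 3 `COc1ccc(-c2c(Nc3ccc(NC(C)=O)cc3)c3ccc(OC)cc3oc2=O)cc1` stands at > 100000 nM and this is a limit of the assay, not a number.

The measured steps all concern the group on an aromatic carbon. Methyl in place of ethoxy gives a 2.4-fold higher number from compound 1 to compound 2 (0.38 log units; beyond the scatter) and acetamido in place of ethoxy gives an at least 3.2-fold higher number from compound 1 to compound 3 (0.50 log units; beyond the scatter) while acetamido in place of methyl gives an at least 1.3-fold higher number from compound 2 to compound 3 (0.12 log units; that floor lies within the scatter) as the last of the three.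

Compound 4 `COc1ccc(-c2c(Nc3ccc(NC(C)=O)cc3)c3ccc(O)cc3oc2=O)cc1` changes a different place: hydrogen in place of methyl on an oxygen on an aromatic ring with hydrogen in place of methyl on an oxygen on an aromatic ring, that is, methoxy to hydroxy. Among the measured compounds shown here, no measured step covers this change directly. The scale of change so far is set by a 2.4-fold higher number from compound 1 to compound 2 (0.38 log units; beyond the scatter) and on that scale no step beyond the scatter is expected in this assay for this change. The expected step is a number no higher from compound 3 to compound 4 (the limit leaves the size open) and an expected outcome may again be only a limit. The estimated value for compound 4 is 100000 nM within an expected range of 40000 nM to 200000 nM.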

Compound 4, half-maximal inhibitory concentration: > 100000 nM
Compound 4 ended at the assay's limit (the forecaster's own chance of this, stated with the estimate: 50%); the middle value lies on the limit itself.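

No step can be read from compound 3 to compound 4, since both stand at a limit and not at a number in this assay: the limit of > 100000 nM in this assay, at which 2 of the 4 values shown sit.

The compounds shown leave open what methoxy to hydroxy does to antiproliferative activity when the acetamido group is present.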